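The source may hold more compounds than are shown below. What is called first, only, known or untested is meant among the compounds shown, and "the series" means these compounds.

Compound 1 `COc1ccc(S(=O)(=O)NC(=O)Nc2ccc(Cl)cc2)s1` gives 93%; compound 2 `CSc1ccc(S(=O)(=O)NC(=O)Nc2ccc(Cl)cc2)s1` gives 29%; compound 3 `CC(C)c1ccc(S(=O)(=O)NC(=O)Nc2ccc(Cl)cc2)s1` gives 42%, all in a functional assay on the whole organism (6C3HED cells, Mus musculus) for inhibition, at a dose of 150 mg/kg by the oral route; on this read-out lower numbers stand for less inhibition and higher numbers for more inhibition at the one dose given (going by the name of the read-out).

Among these three, compound 2 stands lowest in this assay: compound 3 lies a number 13 percentage points higher from compound 2 to compound 3 (beyond the scatter), and compound 1 lies far higher, as the step of a number 64 percentage points lower from compound 1 to compound 2 (beyond the scatter) shows. Compound 4 `CCc1ccsc1S(=O)(=O)NC(=O)Nc1ccc(Cl)cc1` differs from compound 2 as follows: 3-ethylthiophen-2-yl in place of 5-(methylsulfanyl)thiophen-2-yl on a sulfonyl sulfur.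

Among the measured compounds shown here, no measured step reproduces this change exactly. The closest is the modest step of a number 13 percentage points higher from compound 2 to compound 3 (beyond the scatter), where an alkyl group took the place of methylsulfanyl on the same ring and gave a small rise in inhibition. The steps of a number 64 percentage points lower from compound 1 to compound 2 (beyond the scatter) and a number 51 percentage points lower from compound 1 to compound 3 (beyond the scatter) show that changes on this ring can be large, but none of them moves the substituent to another ring carbon, so the direction here is uncertain. Compound 4 is therefore expected to lie somewhat higher than compound 2, by about a number 16 percentage points higher from compound 2 to compound 4 (beyond the scatter), with wide uncertainty. The estimate for compound 4 in this assay is 45%, within a range from 15% to 80%.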

Compound 4, a percentage reported as inhibition, in the whole organism at one dose (the size of the read-out at that dose, not a potency): 21%
The estimate for compound 4 lay 24 percentage points above the measured number; low and high end bracket the measured number.
By their numbers in this assay, from the lowest: compounds 4 and 2 (each within the scatter of the next); then compound 3; then compound 1.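

In this assay, 3-ethylthiophen-2-yl in place of 5-(methylsulfanyl)thiophen-2-yl on a sulfonyl sulfur gives a number 8 percentage points lower from compound 2 to compound 4 (within the scatter) and thus no change that can be told from the scatter. Measured against 5-methoxythiophen-2-yl, the same group gives a number 72 percentage points lower from compound 1 to compound 4 (beyond the scatter) and adds a further compound that stands well apart from compound 1, the only one of the four with a high number. No measurement at hand accounts for these differences.

Compound 4 differs from compound 2 in both the group and the ring carbon that carries it, so the effects of these two changes cannot be separated. On these data alone, it also remains open whether the high number of compound 1 is specific to methoxy or would carry over to an ethoxy or dimethylamino group on the same ring.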